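From diethylamino to diisopropylamino: a small step at the amine

The source may report more compounds than this note shows. Statements on the series, on what has been measured and on what is new or still open speak of the compounds shown alone.

Compound 1 `Cc1cc(=O)c2c(O)cc(OCc3ccccc3)c([C@H]3CCN(C)C[C@H]3O)c2o1` gives 14%
Compound 2 `CCN(CC)Cc1c(O)c([C@H]2CCN(C)C[C@H]2O)c2oc(C)cc(=O)c2c1O` gives 27%
Compound 3 `Cc1cc(=O)c2c(O)c(CN3CCN(C(=O)OC(C)(C)C)CC3)c(O)c([C@H]3CCN(C)C[C@H]3O)c2o1` gives 6%

These numbers come from a functional assay on MIA PaCa-2 cells (Homo sapiens) for inhibition, read by MTT assay, with a stated time of 48 h, tested at 10 uM (a higher number here means more inhibition of growth at the concentration tested, a lower number less inhibition of growth), and compound 2 stands highest of the three, with a distance to each of the other two that lies beyond the usual scatter. Compound 4 `Cc1cc(=O)c2c(O)c(CN(C(C)C)C(C)C)c(O)c([C@H]3CCN(C)C[C@H]3O)c2o1` has not been measured yet. It keeps everything in compound 2 except one group. The change diisopropylamino in place of diethylamino on a saturated chain carbon bound to an aromatic carbon is diisopropylamino in place of diethylamino on a saturated chain carbon bound to an aromatic carbon. Neither group has a ring or a net charge, and the swap adds only carbon atoms. Among the measured compounds shown here, no two measured compounds differ in one place alone, so no measured step shows what such a swap does. The starting point is therefore compound 2 at 27% and a step beyond the scatter in this assay is not expected in either direction. The estimated a number 4 percentage points lower from compound 2 to compound 4 (within the scatter) stays within the usual scatter. For compound 4 the estimated value is 23% with an expected range from 8% to 38% once it is measured.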

Compound 4, percent growth inhibition at one concentration: 11%
Estimate against measurement, compound 4: 12 percentage points above; the range from low to high includes it.
By their numbers in this assay, from the lowest: compounds 3, 4 and 1 (each within the scatter of the next); then compound 2.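

In this assay, diisopropylamino in place of diethylamino, a swap that adds only carbon atoms, gives a number 16 percentage points lower from compound 2 to compound 4 (beyond the scatter). Among the compounds shown here, this is the first reading of a change in one place alone, and it shows that growth inhibition responds to what the two alkyl groups on this amine are, even though the ring count, net charge and hydrogen-bond counts stay the same. No measurement of any property of these groups comes with the result, so the reason for the drop remains unknown.

The compounds shown leave open what other amines do at this place: dimethylamino, or pyrrolidin-1-yl with its ring, would show whether diethylamino stands out or is one point on a wider pattern. Also open, as far as these compounds go, is whether this step holds at other concentrations, as the read-out comes from a single one.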